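Chloro addition on the fused core of compound 1

The source may report more compounds than this note shows. Statements on the series, on what has been measured and on what is new or still open speak of the compounds shown alone.

Measured so far:
compound 1 `ClCc1cccc(Cn2cnc3c(Cl)ncnc32)c1` — 3980 nM
compound 2 `ClCc1ccc(Cn2cnc3nc(Cl)nc(Cl)c32)cc1` — 2450 nM

In a functional assay on KM12 cells (Homo sapiens) for cytotoxicity, read by sulforhodamine B assay, with a stated time of 48 h (on this read-out higher numbers stand for lower toxicity in this test and lower numbers for higher toxicity in this test), compound 1 gives 3980 nM and compound 2 gives 2450 nM, and the two numbers lie within the scatter of each other, so no ordering between them is claimed. Compound 3 `ClCc1cccc(Cn2cnc3c(Cl)nc(Cl)nc32)c1` is not yet measured. It differs from compound 1 by chloro in place of hydrogen on an aromatic carbon. Among the measured compounds shown here, no measured pair of this series isolates that change, so the size of the step in this assay is open. Compound 3 is expected to land near compound 1, with a 1.3-fold lower number from compound 1 to compound 3 (0.12 log units; within the scatter) a step not clearly beyond the scatter. The estimate for compound 3 is 3000 nM, range 1200 nM to 7500 nM.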

Compound 3, concentration lethal to 50% of the cells: 7940 nM
Compound 3: middle estimate off by 2.6-fold (0.42 log units), on the low side, outside the stated range (above it).
By their numbers in this assay, from the lowest: compounds 2, 1 and 3 (each within the scatter of the next, the first and the last beyond it).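

In this assay, among the compounds shown here, the single change of chloro in place of hydrogen on an aromatic carbon, between two ring nitrogen atoms, now has a measured size: a 2.0-fold higher number from compound 1 to compound 3 (0.30 log units; within the scatter), so chloro at this position gives no step beyond the scatter on the core of compound 1. Nothing at hand bears on the reason for this reading. Going by these compounds, whether an amine, a methoxy group or a longer chain at this position would give a step beyond the scatter remains open. This single pair also leaves open whether the chloro step carries over to other compounds of the series.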